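A Methyl Group Added to Compound 2

The source may report more compounds than this note shows. Statements on the series, on what has been measured and on what is new or still open speak of the compounds shown alone.

Measured compounds:
compound 1 `COC1=CC(=O)c2c(c(COc3ccc(F)cc3)c(C)n2C)C1=O`: 850 nM
compound 2 `COC1=CC(=O)c2c(c(COC(N)=O)cn2C)C1=O`: 40 nM

Both values come from a functional assay on V79-379A cells (Cricetulus griseus) for cytotoxicity, read by MTT assay, in the presence of a further agent that is not named here; a lower number here means a stronger inhibitor, a higher number a weaker inhibitor. Of the two compounds, compound 2 40 nM has the lower number and is the stronger inhibitor, and the gap to compound 1 850 nM lies beyond the scatter.

The next compound, compound 3 `COC1=CC(=O)c2c(c(COC(N)=O)c(C)n2C)C1=O`, keeps the (carbamoyloxy)methyl group of compound 2 and puts methyl in place of hydrogen on an aromatic carbon. Going by the values given here, no measured pair isolates this change. Compound 1 also carries a methyl group on the shared core, yet it differs in its other side group as well, so its value (850 nM) offers only a loose hint that the number may rise. A modest loss in this assay is therefore expected, of about the size of the scatter and towards a higher number. The estimated change is a 2.0-fold higher number from compound 2 to compound 3 (0.30 log units; within the scatter) and remains uncertain. Compound 3 is expected to measure about 80 nM (estimated range 20 nM to 300 nM) when tested.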

Compound 3, half-maximal inhibitory concentration: 300 nM
For compound 3 the middle estimate is 3.8-fold (0.57 log units) below the measured one, within the range that was stated.
By their numbers in this assay, from the lowest: compound 2; then compound 3; then compound 1.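

In this assay, going by these compounds alone, methyl in place of hydrogen on an aromatic carbon, next to the ring nitrogen, gives a 7.5-fold higher number from compound 2 to compound 3 (0.88 log units; beyond the scatter) and so provides the first single-change reading at this position, showing that this one added carbon moves the number beyond the scatter. With that methyl group in place, carbamoyl in place of 4-fluorophenyl on an oxygen on a saturated carbon gives a 2.8-fold lower number from compound 1 to compound 3 (0.45 log units; beyond the scatter) and also lies beyond the scatter, so compound 3 joins compound 1 and compound 2 through two single changes, and the side group still matters on the methylated core. Nothing given here accounts for the loss of potency that comes with the methyl group.

On these data alone, it remains open whether ethyl or a chlorine atom on the same aromatic carbon would move the number further than methyl does, or whether an amine in place of the carbamoyl group would keep compound 2 at its low number. Also open is whether the methyl step would have the same size with a 4-fluorophenyl group on the oxygen, where only the methylated form, compound 1, is shown.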